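The source may hold more compounds than are shown below. What is called first, only, known or untested is meant among the compounds shown, and "the series" means these compounds.

Working notes on the series. In a functional assay on NCI-H1993 cells (Homo sapiens) for inhibition, read by CCK-8 assay, with a stated time of 72 h (on this read-out higher numbers stand for weaker inhibition and lower numbers for stronger inhibition), compound 1 `CCC(c1cc2cccnc2cc1F)n1cnc2ncc(-c3cn[nH]c3)nc21` gives "not determined" (no result reported) and compound 2 `CCC(c1cc2cccnc2cc1F)n1cnc2ncc(-c3cnn(CCO)c3)nc21` gives "not determined" (no result reported); for both, no number was reported. Among the compounds with values here, compound 3 `CC(c1cc2cccnc2cc1F)n1cnc2ncc(-c3ccc(C(N)=O)c(F)c3)nc21` is the only entry with a number: in this assay compound 3 gives 19.5 nM, so it stands alone and no comparison between measured compounds can be drawn. Compound 4 `CCC(c1cc2cccnc2cc1F)n1cnc2ncc(-c3ccc(C(N)=O)c(F)c3)nc21` is the next entry to be measured in this assay. Relative to compound 3 the change is methyl in place of hydrogen on a saturated chain carbon, two bonds along the chain from an aromatic carbon and an aromatic nitrogen. Within the data shown here, with no step between measured compounds available, the expectation rests on the change alone, and a step of a size within the usual scatter is expected, in no firm direction. For compound 4 the expected step is a 1.2-fold lower number from compound 3 to compound 4 (0.09 log units; within the scatter), which makes the estimate for compound 4 in this assay 16 nM, with a range from 6 nM to 45 nM.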

Compound 4, half-maximal inhibitory concentration: 226 nM
Beside the measured number, compound 4's estimate is 14-fold (1.15 log units) below it; the measured number lies above the stated range.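

In this assay, within the data shown here, methyl in place of hydrogen on this saturated chain carbon gives a 12-fold higher number from compound 3 to compound 4 (1.06 log units; beyond the scatter), the first step and one beyond the scatter. This position therefore responds strongly to a single added carbon, with the methyl to ethyl change going towards weaker inhibition. Nothing available bears on the reason for this step. Steps involving compound 1 and compound 2 cannot be read, as neither has a number. Open, from the compounds shown here alone, is how a propyl chain or a hydroxymethyl group at this carbon would read out.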